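The source may report more compounds than this note shows. Statements on the series, on what has been measured and on what is new or still open speak of the compounds shown alone.

Working notes on the series: two compounds have numbers so far, compound 1 `Cc1cc2c(c(N)nn2C)c(=O)[nH]1` and compound 2 `COC(=O)CCc1c(C)[nH]c(=O)c2c(N)nn(C)c12`. In a physicochemical assay for solubility, read by HPLC (a lower number here means a less soluble compound, a higher number a more soluble compound), compound 1 gives 1220 ug/mL. In this assay, compound 2 gives 469 ug/mL, the lower of the two numbers. Next comes compound 3 `Cc1[nH]c(=O)c2c(N)nn(C)c2c1-c1ccccc1`, with phenyl in place of 2-(methoxycarbonyl)ethyl on an aromatic carbon, ortho to a methyl group: phenyl in place of 2-(methoxycarbonyl)ethyl on an aromatic carbon. Among the compounds with values here, only one measured step bears on this change: a 2.6-fold lower number from compound 1 to compound 2 (0.42 log units; beyond the scatter), modest and beyond the scatter, where 2-(methoxycarbonyl)ethyl took the place of hydrogen on an aromatic carbon. Within the data shown here, no measured compound carries phenyl, so that step offers a scale rather than a direct reading, and the direction is uncertain. Among the measured compounds shown here, with only that step as a guide, a modest move toward a lower number in this assay is expected. For the measured compounds named here, the estimated change is a 2.6-fold lower number from compound 2 to compound 3 (0.42 log units; beyond the scatter), similar in size to the one measured step. For compound 3 the estimated solubility is 180 ug/mL, with an expected range of 50 ug/mL to 500 ug/mL.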

Compound 3, solubility: 2 ug/mL
Compound 3: the middle estimate sits 90-fold (1.95 log units) above what was measured; measured number below the stated range.
By their numbers in this assay, from the lowest: compound 3; then compound 2; then compound 1.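

In this assay, this aromatic carbon, ortho to a methyl group, can carry a far larger change than the first substitution indicated: a 2.6-fold lower number from compound 1 to compound 2 (0.42 log units; beyond the scatter) is modest, whereas a 230-fold lower number from compound 2 to compound 3 (2.37 log units; beyond the scatter) is large, and a 610-fold lower number from compound 1 to compound 3 (2.79 log units; beyond the scatter) is larger again. The exchange keeps the count at 6 heavy atoms but puts a six-membered aromatic ring of carbon only, with 0 hydrogen-bond acceptors, in place of a chain with no ring and 2 hydrogen-bond acceptors, so across this pair the number does not follow heavy-atom count. No accompanying measurement is available to assign a reason for the size of these steps.

From the compounds shown here alone, it remains open whether the large step follows the entry of phenyl or the departure of 2-(methoxycarbonyl)ethyl, a question that cyclohexyl, pyridyl, or a propanoic acid chain at this position could help separate. Also open, going by these compounds, is whether an amine placed on the phenyl ring would change the number in this assay while the aromatic ring stays in place.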